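Amino in place of hydrogen on compound 3

A few compounds are considered here, and "the series" means these few. Any claim that something is new, unique, unknown or untested is made for them only; others in the source may bear on it.

Three compounds share one core and differ in a single group: compound 1 `COc1cc(-n2c(-c3ccc(Br)cc3)cn(C(C)=O)c2=O)cc(OC)c1OC`, compound 2 `COc1cc(-n2c(-c3ccc(Cl)cc3)cn(C(C)=O)c2=O)cc(OC)c1OC` and compound 3 `COc1ccc(-c2cn(C(C)=O)c(=O)n2-c2cc(OC)c(OC)c(OC)c2)cc1`. In a functional assay on K-562R cells (Homo sapiens) for cytotoxicity, read by MTT assay, with a stated time of 48 h (on this read-out lower numbers stand for stronger inhibition and higher numbers for weaker inhibition), compound 1 gives 900 nM and compound 3 gives 9500 nM. The entry for compound 2 reads "not determined" (no result reported), so it adds no number. Compound 3 thus holds the higher of the two available numbers, the weaker end of this short series.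

Compound 4 `COc1ccc(-c2cn(C(C)=O)c(=O)n2-c2cc(OC)c(OC)c(OC)c2)cc1N` is compound 3 with amino in place of hydrogen on an aromatic carbon, ortho to a methoxy group and meta to a large group, the change from 4-methoxyphenyl to 3-amino-4-methoxyphenyl: amino in place of hydrogen on an aromatic carbon.

Among the compounds with values here, only one measured step bears on this, and only indirectly. Methoxy in place of bromo on an aromatic carbon gives an 11-fold higher number from compound 1 to compound 3 (1.02 log units; beyond the scatter), large and beyond the scatter. That is a different change, but it shows that one substituent swap on this ring can move the number considerably in this assay. Within the data shown here, no measured compound carries an amino group, so the direction rests on little. With compound 3 at the high end, a move toward a lower number is the working expectation, of moderate size. The expected step is a 4.8-fold lower number from compound 3 to compound 4 (0.68 log units; beyond the scatter). For compound 4 the estimated value is 2000 nM, with an expected range from 200 nM to 9000 nM.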

Compound 4, half-maximal inhibitory concentration: 49300 nM
The estimate for compound 4 lay 25-fold (1.39 log units) below the measured number; measured number outside the range, above it.
By their numbers in this assay, from the lowest: compound 1; then compound 3; then compound 4.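

In this assay, within the data shown here, amino in place of hydrogen on this aromatic carbon, ortho to a methoxy group, gives a 5.2-fold higher number from compound 3 to compound 4 (0.72 log units; beyond the scatter), so the first change at this carbon moves away from stronger inhibition, although compound 3 already stood at the weak end of the series. Replacing 4-bromophenyl with 3-amino-4-methoxyphenyl gives a 55-fold higher number from compound 1 to compound 4 (1.74 log units; beyond the scatter), which is larger than the methoxy-for-bromo step alone, an 11-fold higher number from compound 1 to compound 3 (1.02 log units; beyond the scatter), and leaves compound 4 as the weakest of the three compounds with a number. Neither step comes with any data that would account for it. The compounds shown leave open whether the higher number belongs to amino alone or would also follow from another group on this carbon, such as hydroxyl, fluoro, methyl or acetamido. From the compounds shown here alone, it is also open whether amino at this carbon would cost as much alongside bromo in place of the methoxy group, and compound 2 gives no number that could place chloro in this comparison.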